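Fluoro for Methoxy Carried onto a Second Core

This account rests on a few compounds, and the source may have more. Where it says the series, first, only, none or still open, it means among the compounds named here.

Compound 1 `COc1ccc(/C=C/C(=O)OC[C@@H](OCc2ccccc2)[C@H]2OC(=O)C=C[C@H]2OCc2ccccc2)cc1` and compound 2 `O=C1C=C[C@@H](OCc2ccccc2)[C@@H]([C@@H](COC(=O)/C=C/c2ccc(F)cc2)OCc2ccccc2)O1` share one core. In a functional assay on Jurkat cells (Homo sapiens) for antiproliferative activity, read by MTT assay, with a stated time of 6 days (a higher number here means a weaker inhibitor, a lower number a stronger inhibitor), compound 1 gives 10300 nM, and compound 2 gives 4160 nM. The change between them, (fluoro in place of methoxy on an aromatic carbon), made a 2.5-fold lower number from compound 1 to compound 2 (0.39 log units; beyond the scatter). Compound 3 `COc1ccc(/C=C/C(=O)OC[C@@H](OC(C)=O)[C@H]2OC(=O)C=C[C@H]2OC(C)=O)cc1` rests on a different core, and the difference between the two cores is not broken down here. In this assay compound 3 gives 2590 nM, a number that lies within the usual scatter of compound 2 and beyond it only relative to compound 1. Compound 4 `CC(=O)O[C@@H]1C=CC(=O)O[C@@H]1[C@@H](COC(=O)/C=C/c1ccc(F)cc1)OC(C)=O` has not yet been measured. It differs from compound 3 by fluoro in place of methoxy on an aromatic carbon, the same change that was made from compound 1 to compound 2, at a place described in the same words. Because the earlier step was a 2.5-fold lower number from compound 1 to compound 2 (0.39 log units; beyond the scatter), a step of similar size and direction is expected here, namely a 2.4-fold lower number from compound 3 to compound 4 (0.37 log units; beyond the scatter). Compound 4 is therefore estimated at 1100 nM, with 400 nM to 3000 nM as the expected range.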

Compound 4, half-maximal inhibitory concentration: 5320 nM
Estimate against measurement, compound 4: 4.8-fold (0.68 log units) below; the measured number lies above the stated range.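

On the second core, fluoro in place of methoxy gave a 2.1-fold higher number from compound 3 to compound 4 (0.31 log units; beyond the scatter) in this assay, so the lowering seen on the first core did not carry over. The two steps run in opposite directions, and the gap between them is larger than scatter alone would account for: the same change on two cores in this assay, a 2.5-fold lower number (0.39 log units; beyond the scatter) from compound 1 to compound 2 and a 2.1-fold higher number (0.31 log units; beyond the scatter) from compound 3 to compound 4, 5.1-fold (0.71 log units) apart, beyond the scatter of two such steps. This shows that, in this series, the effect of this change depends on the core that carries it, so a step measured on one core is a poor guide to the other, but it does not show which difference between the cores is responsible, and each direction rests on a single pair of compounds.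

The compounds shown leave open whether a group such as chloro or an amine at the same place on the aromatic ring would also behave differently on the two cores. They also leave open how the methoxy to fluoro change would behave on any third core, and so whether either direction is the more usual one.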